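Pyridyl amide series: chlorine position on pyridine

The source may report more compounds than this note shows. Statements on the series, on what has been measured and on what is new or still open speak of the compounds shown alone.

Measured so far:
compound 1 `Cc1noc(C)c1-c1cnc(N)c(Oc2ccc(C(=O)Nc3ccc(Cl)cn3)cc2)n1` — 9180 nM
compound 2 `Cc1noc(C)c1-c1cnc(N)c(Oc2ccc(C(=O)Nc3cc(Cl)ccn3)cc2)n1` — > 100000 nM
compound 3 `Cn1cc(-c2cnc(N)c(Oc3ccc(C(=O)Nc4ccc(Cl)cn4)cc3)n2)cn1` — 6160 nM

In a functional assay on LoVo cells (Homo sapiens) for inhibition, read by MTT assay, with a stated time of 72 h (a higher number here means a weaker inhibitor, a lower number a stronger inhibitor), compound 1 gives 9180 nM. The value of compound 2 in this assay is a limit of the assay, not a number (the limit of > 100000 nM in this assay, at which 1 of the 3 values shown sits). The change 4-chloropyridin-2-yl in place of 5-chloropyridin-2-yl on an amide-type nitrogen gave an at least 10-fold higher number from compound 1 to compound 2 (1.03 log units; beyond the scatter). The two cores differ as 1-methyl-1H-pyrazol-4-yl in place of 3,5-dimethyl-1,2-oxazol-4-yl on an aromatic carbon, and that step gave a 1.5-fold lower number from compound 1 to compound 3 (0.17 log units; within the scatter).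

Compound 4 `Cn1cc(-c2cnc(N)c(Oc3ccc(C(=O)Nc4cc(Cl)ccn4)cc3)n2)cn1` is not yet measured. It carries the same change as compound 2 does, (4-chloropyridin-2-yl in place of 5-chloropyridin-2-yl on an amide-type nitrogen), and the place lines read alike. The step from compound 3 is expected as an 11-fold higher number from compound 3 to compound 4 (1.06 log units; beyond the scatter), resting on the measured step of an at least 10-fold higher number from compound 1 to compound 2 (1.03 log units; beyond the scatter). For compound 4 the estimate is 70000 nM, between 25000 nM and 300000 nM, with a fair chance the assay reports only a limit.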

Compound 4, half-maximal inhibitory concentration: 26600 nM
Estimate against measurement, compound 4: 2.6-fold (0.42 log units) above; low and high end bracket the measured number.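

In this assay, 4-chloropyridin-2-yl in place of 5-chloropyridin-2-yl on the amide-type nitrogen again gives a weaker inhibitor on the second core, with a 4.3-fold higher number from compound 3 to compound 4 (0.64 log units; beyond the scatter), so the direction of the change carries over across these two pairs: the same change on two cores in this assay, an at least 10-fold higher number (1.03 log units; beyond the scatter) from compound 1 to compound 2 and a 4.3-fold higher number (0.64 log units; beyond the scatter) from compound 3 to compound 4; the limit leaves it open whether they differ. Read the other way, 1-methyl-1H-pyrazol-4-yl in place of 3,5-dimethyl-1,2-oxazol-4-yl gives an at least 3.7-fold lower number from compound 2 to compound 4 (0.57 log units; beyond the scatter), set against the earlier core step: the same change on two cores in this assay, a 1.5-fold lower number (0.17 log units; within the scatter) from compound 1 to compound 3 and an at least 3.7-fold lower number (0.57 log units; beyond the scatter) from compound 2 to compound 4; the limit leaves it open whether they differ. Compound 2 gives > 100000 nM, which is a limit of the assay, so the size of the change on its core is not fixed and the pairs show no equal or unequal effect.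

Two cores are too few to support a general rule for the series. On these data alone, it remains open whether the same preference holds when a nitrile or a methoxy group replaces the chlorine on the pyridine.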